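The source may hold more compounds than are shown below. What is called first, only, known or untested is meant among the compounds shown, and "the series" means these compounds.

In a functional assay on TSGH 8302 cells (Homo sapiens) for cytotoxicity (on this read-out higher numbers stand for weaker inhibition and lower numbers for stronger inhibition), compound 1 `Cc1ccc(S(=O)(=O)N/C(=N\O)Nc2ccc(Cl)cc2)cc1` gives 46 ug/mL and compound 2 `O=S(=O)(N/C(=N\O)Nc1ccc(Cl)cc1)c1cc2ccccc2s1` gives 76 ug/mL. Among the measured compounds shown here, these two values lie within the usual scatter of each other, so compound 1 stands level with the only other compound measured so far. Compound 3 `N#Cc1c(Cl)cccc1Oc1ccc(S(=O)(=O)N/C(=N\O)Nc2ccc(Cl)cc2)cc1` keeps the core of compound 1 and changes one group: 3-chloro-2-cyanophenoxy in place of methyl on an aromatic carbon. In words, 3-chloro-2-cyanophenoxy replaces methyl on an aromatic carbon, para to a large group. For the measured compounds named here, no measured pair shows what such a swap does in this assay, so any forecast here is loose. Going by the values given here, the one hint is that compound 2 also differs from compound 1 in structure, yet compound 2 at 76 ug/mL stays within the scatter. No step beyond the scatter is therefore expected, in either direction, and the estimated change is a 1.2-fold lower number from compound 1 to compound 3 (0.06 log units; within the scatter). Compound 3 is expected at 40 ug/mL, with an estimated range from 14 ug/mL to 100 ug/mL.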

Compound 3, half-maximal inhibitory concentration: 168 ug/mL
Compound 3: the middle estimate sits 4.2-fold (0.62 log units) below what was measured, and the stated range ends below it.
By their numbers in this assay, from the lowest: compounds 1 and 2 (each within the scatter of the next); then compound 3.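

Replacing methyl with 3-chloro-2-cyanophenoxy on this aromatic carbon, para to a large group, gives in this assay a 3.7-fold higher number from compound 1 to compound 3 (0.56 log units; beyond the scatter), which means weaker inhibition of the cells. Among the compounds shown here, this is the first change at a single place in this set, and it shows that the position is not indifferent to what sits there: a modest loss follows when methyl is replaced by a larger group carrying its own aromatic ring. No measurement shown here explains why the number rises.

On these data alone, the swap brings in the ether oxygen, the ring, the chlorine and the nitrile all at once, so the share of each in the step remains unknown. Whether a plain phenoxy, a methoxy or an amine at this place would stay close to methyl remains an open question.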